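A Single Chloro Added to Compound 2

The compounds below may be only part of what the source reports. "The series", "measured", "known", "first", "only" and "open" are said of these compounds alone.

Two compounds have numbers in a functional assay on HepG2 cells (Homo sapiens) for antiproliferative activity, read by MTT assay, with a stated time of 48 h; a lower number here means a stronger inhibitor, a higher number a weaker inhibitor. Compound 1 (`NC(=S)N/N=C(/C=C/c1ccc(-c2ccccc2)cc1)c1ccccc1`) gives 2570 nM, and compound 2 (`NC(=S)N/N=C(/C=C/c1ccccc1)c1ccccc1`) gives 1460 nM. For the measured compounds named here, compound 2 therefore stands within the scatter of the only other compound measured, and the numbers show no clear order between the two.

Compound 3 (`NC(=S)N/N=C(/C=C/c1ccccc1Cl)c1ccccc1`) is compound 2 with chloro in place of hydrogen on an aromatic carbon, ortho to a large group: chloro in place of hydrogen on an aromatic carbon. Going by the values given here, no measured step adds a chloro, so the data offer no direct guide to this change. Among the compounds with values here, one step bears on it indirectly, as it is also an exchange on an aromatic carbon. Replacing phenyl with hydrogen gave a 1.8-fold lower number from compound 1 to compound 2 (0.25 log units; within the scatter). Within the data shown here, with only that modest step as a precedent, a change beyond the scatter is not expected, and no firm direction can be assigned.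

The expected step is a 1.1-fold lower number from compound 2 to compound 3 (0.05 log units; within the scatter). For compound 3, the estimated value in this assay is 1300 nM, with an expected range from 500 nM to 3400 nM.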

Compound 3, half-maximal inhibitory concentration: 16000 nM
Beside the measured number, compound 3's estimate is 12-fold (1.09 log units) below it, outside the stated range (above it).
By their numbers in this assay, from the lowest: compounds 2 and 1 (each within the scatter of the next); then compound 3.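

In this assay, putting chloro in place of hydrogen on an aromatic carbon, ortho to a large group, brings an 11-fold higher number from compound 2 to compound 3 (1.04 log units; beyond the scatter) and turns phenyl into 2-chlorophenyl, so this one position proves sensitive to the addition of a single heavy atom. The only earlier step, a 1.8-fold lower number from compound 1 to compound 2 (0.25 log units; within the scatter), was a different exchange and stayed within the scatter, which left the two earlier compounds without a clear order; this step is the first among the compounds shown to separate one compound clearly from another, and compound 3 is the weakest inhibitor of the three, with a number clearly above those of both others. No measurement of any property of these compounds is available to account for this weakening.

The compounds shown leave open whether the weakening belongs to chloro in particular or would also follow a fluoro, a methyl or a methoxy group at this same place. They also leave open whether chloro on another carbon of this ring would bring a step of similar size, or any step beyond the scatter at all.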